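Inverting one stereocentre in an antiproliferative amide series

The compounds below may be only part of what the source reports. "The series", "measured", "known", "first", "only" and "open" are said of these compounds alone.

Compound 3 `CCn1c(C(=O)N[C@H](CO)CCO)ccc1C(CC)(CC)c1ccc(OCS(=O)(=O)c2ccccc2)c(C)c1` gives 28500 nM in a functional assay on MCF7 cells (Homo sapiens) for antiproliferative activity, read by MTT assay, with a stated time of 24 h (a higher number here means a weaker inhibitor, a lower number a stronger inhibitor), and compound 2 `CCn1c(C(=O)N[C@H](CO)C(C)C)ccc1C(CC)(CC)c1ccc(OCS(=O)(=O)c2ccccc2)c(C)c1` gives 25500 nM there, so the two stand level within the scatter. Compound 1 `CCn1c(C(=O)N[C@H](C)C(=O)OC)ccc1C(CC)(CC)c1ccc(OCS(=O)(=O)c2ccccc2)c(C)c1` is recorded in this assay only as a limit, > 50000 nM.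

The next structure is compound 4 `CCn1c(C(=O)N[C@@H](CO)CCO)ccc1C(CC)(CC)c1ccc(OCS(=O)(=O)c2ccccc2)c(C)c1`. Relative to compound 3, the change is the two compounds have the same atoms and bonds and differ only in configuration as drawn: 1 of 1 stereo elements differ; a stereocentre at a saturated chain carbon is drawn S in compound 3 and R in compound 4: a stereocentre at a saturated chain carbon is drawn S in compound 3 and R in compound 4. For the measured compounds named here, no measured pair in the set isolates a change of configuration, so the evidence is indirect. The closest measured guide is a 1.1-fold higher number from compound 2 to compound 3 (0.05 log units; within the scatter), a change of the group on that same carbon that stays within the scatter. The steps of an at least 1.9-fold lower number from compound 1 to compound 2 (0.29 log units; that floor lies within the scatter) and an at least 1.7-fold lower number from compound 1 to compound 3 (0.24 log units; that floor lies within the scatter) alter the group on the amide-type nitrogen, and their floors also lie within the scatter. None of the three steps is shown to exceed the scatter, so no shift beyond the scatter is expected in this assay, and no direction is favoured. The expected change is a 1.1-fold higher number from compound 3 to compound 4 (0.02 log units; within the scatter). Compound 4 may also return no number, given (the limit of > 50000 nM in this assay, at which 1 of the 3 values shown sits). For compound 4 the estimated value is 30000 nM, with an expected range from 15000 nM to 50000 nM.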

Compound 4, half-maximal inhibitory concentration: 27400 nM
Estimate against measurement, compound 4: 1.1-fold (0.04 log units) above; the range from low to high includes it.
By their numbers in this assay, from the lowest: compounds 2, 4 and 3 (each within the scatter of the next). At a limit, above all of these: compound 1.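

Inverting this stereocentre gives the only pair in the set that isolates configuration, and in this assay the result is a 1.0-fold lower number from compound 3 to compound 4 (0.02 log units; within the scatter), a comparison free of any other change: the fact that compounds 3 and 4 differ only in the configuration as drawn

With the 3-hydroxy-1-(hydroxymethyl)propyl group on the amide-type nitrogen, the configuration drawn at this saturated chain carbon therefore does not separate the two forms in this assay, and the R form also stands level with the 1-(hydroxymethyl)-2-methylpropyl analogue, at a 1.1-fold higher number from compound 2 to compound 4 (0.03 log units; within the scatter). Against the 1-(methoxycarbonyl)ethyl analogue only a floor can be given, an at least 1.8-fold lower number from compound 1 to compound 4 (0.26 log units; that floor lies within the scatter), so this step is not shown to exceed the scatter, and its true size stays unknown: the limit of > 50000 nM in this assay, at which 1 of the 4 values shown sits.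

The compounds shown leave open whether configuration at this carbon would matter with another group on it, such as the 1-(hydroxymethyl)-2-methylpropyl group, for which only one configuration appears here. They also leave open whether an amine or a carboxylic acid in place of a hydroxyl group on this chain would move the number beyond the scatter, and whether the two configurations would then part.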